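The source may report more compounds than this note shows. Statements on the series, on what has been measured and on what is new or still open speak of the compounds shown alone.

Compound 1 `Nc1ccc2cccc(OCCC(F)(F)F)c2n1`: 722 nM.
Compound 2 `CC(CC(C)(C)C)Oc1cccc2ccc(N3CCCCC3)nc12`: a limit, > 2000 nM.
Compound 3 `CC(CC(C)(C)C)Oc1cccc2ccc(N3CCCC3)nc12`: a limit, > 2000 nM.

In an assay on cells with melanin-concentrating hormone receptor 1 (Homo sapiens) as the target, read by radioligand binding (on this read-out lower numbers stand for stronger inhibition and higher numbers for weaker inhibition), compound 1 gives 722 nM. Compound 2 reaches only the limit > 2000 nM. Compound 3 likewise reaches only the limit > 2000 nM. Going by the values given here, compound 1 therefore holds the only number in this assay; the other two values are limits (the limit of > 2000 nM in this assay, at which 2 of the 3 values shown sit). Among the compounds with values here, the single measured step, a step that the two limits leave unreadable from compound 2 to compound 3, concerns a different place on the shared core and cannot be read. Compound 4 `CC(C)=CCOc1cccc2ccc(N)nc12` differs from compound 1 by 2-methylprop-1-en-1-yl in place of 2,2,2-trifluoroethyl on a saturated chain carbon bound to an oxygen on an aromatic ring. Within the data shown here, no measured step bears on this change, since compounds 2 and 3 differ from compound 1 in more than one place. For compound 4 in this assay no shift beyond the scatter is expected, a 1.2-fold lower number from compound 1 to compound 4 (0.08 log units; within the scatter). Compound 4 is estimated at 600 nM, between 150 nM and 2400 nM.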

Compound 4, half-maximal inhibitory concentration: > 2000 nM
Compound 4: a limit, no number; the forecaster's own chance of this, stated with the estimate: 15%; at least 3.3-fold (0.52 log units) between middle value and limit.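

In this assay, going by these compounds alone, the step of an at least 2.7-fold higher number from compound 1 to compound 4 (0.44 log units; beyond the scatter) is the first single change that can be read. On this oxygen, 3-methylbut-2-en-1-yl therefore does not match 3,3,3-trifluoropropyl, though this rests on one pair only. As far as these compounds go, compound 4 gives a limit, not a number, so the full size of the step stays unknown: the limit of > 2000 nM in this assay, at which 3 of the 4 values shown sit.

From the compounds shown here alone, whether the loss follows the missing fluorine atoms or the double bond stays open. A plain 3-methylbutyl chain on the same oxygen would separate the two.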